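Swapping a dichlorophenyl for an indanyl on a thiourea

This account rests on a few compounds, and the source may have more. Where it says the series, first, only, none or still open, it means among the compounds named here.

Three compounds share a thiourea-bearing core: compound 1 `NC(=S)Nc1cccc(OCCCCCN2CCN(c3cccc4ccccc34)C2=O)c1`, compound 2 `NC(=S)Nc1cccc(OCCCCCN2CCN(c3ccc(Oc4ccccc4)cc3)C2=O)c1` and compound 3 `NC(=S)Nc1cccc(OCCCCCCCCNC(=S)Nc2cc(Cl)cc(Cl)c2)c1`. In an ADME assay on Huh-7 cells (Homo sapiens) for cytotoxicity (a lower number here means that less compound is tolerated, a higher number that more compound is tolerated), compound 1 gives 15000 nM. In this assay compound 2 reaches only a limit, > 50000 nM, which is not a number but the edge of what was tested (the limit of > 50000 nM in this assay, at which 1 of the 3 values shown sits). In this assay compound 3 gives 12000 nM; this and the number of compound 1 sit within the usual scatter of each other, so neither can be called more or less tolerated than the other.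

Compound 4 `NC(=S)Nc1cccc(OCCCCCCCCNC(=S)Nc2ccc3c(c2)CCC3)c1` has not yet been measured. It differs from compound 3 in one place: 2,3-dihydro-1H-inden-5-yl in place of 3,5-dichlorophenyl on an amide-type nitrogen. Among the measured compounds shown here, no measured pair shows what such a swap does in this assay, so no direction can be read from the data. The expectation for compound 4 is therefore a step of a 1.3-fold higher number from compound 3 to compound 4 (0.12 log units; within the scatter), that is, nothing beyond the scatter. Compound 4 is expected to give about 16000 nM, somewhere between 6000 nM and 45000 nM.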

Compound 4, half-maximal cytotoxic concentration: 34000 nM
Compound 4: middle estimate off by 2.1-fold (0.33 log units), on the low side; measured number inside the range.
By their numbers in this assay, from the lowest: compounds 3 and 1 (each within the scatter of the next); then compound 4. At a limit, above all of these: compound 2.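

On the amide-type nitrogen whose other neighbour is the thiocarbonyl carbon, putting 2,3-dihydro-1H-inden-5-yl in place of 3,5-dichlorophenyl in this assay gives a 2.8-fold higher number from compound 3 to compound 4 (0.45 log units; beyond the scatter), so more compound is tolerated. This is the only pair shown that differs in one place, which makes it the first direct reading of what a single change does here, and the step is modest but beyond the scatter. Nothing measured here says whether losing the chlorine atoms or gaining the five-membered ring accounts for the step.

A plain phenyl or a 3,5-dimethylphenyl on the same nitrogen would help separate those two parts of the swap. As far as these compounds go, whether the step holds with a shorter or longer chain in the shared core also stays open.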